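The source may hold more compounds than are shown below. What is called first, only, known or untested is meant among the compounds shown, and "the series" means these compounds.

Measured compounds:
compound 1 `COc1cc(/C=N/NC(=O)c2ccncc2)cc(OC)c1O`, 48%
compound 2 `COc1cc(/C=N/NC(=O)c2ccncc2)cc(O)c1O`, 59%
compound 3 `Oc1ccc(/C=N/Nc2nc3ccccc3s2)cc1O`, 44%

All three values come from a physicochemical assay on cells (Homo sapiens), with a stated time of 18 h, tested at 1 uM; a lower number here means a stronger effect, a higher number a weaker effect of the compound at the concentration tested. Compound 2 and compound 1 differ in one place, (methyl in place of hydrogen on an oxygen on an aromatic ring), and that step reads a number 11 percentage points lower from compound 2 to compound 1 (beyond the scatter). Compound 4 `COc1cc(/C=N/Nc2nc3ccccc3s2)ccc1O` is not yet measured and shares its core with compound 3; the difference between the core of compound 3 and the core of compound 2 is not broken down here. The change from compound 3 to compound 4 is methyl in place of hydrogen on an oxygen on an aromatic ring, the same change as from compound 2 to compound 1. On this single precedent the step is expected to be a number 9 percentage points lower from compound 3 to compound 4 (within the scatter), resting on a number 11 percentage points lower from compound 2 to compound 1 (beyond the scatter). With one example only, and that on another core, the estimate is held loosely. Compound 4 is therefore expected to give 35% in this assay, within a range of 24% to 46%.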

Compound 4, a percentage reported as activity, at one concentration (the size of the read-out at that concentration, not a potency): 65%
Beside the measured number, compound 4's estimate is 30 percentage points below it; the whole stated range lies below it.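

In this assay the same change, methyl in place of hydrogen on an oxygen on an aromatic ring, reads a number 21 percentage points higher from compound 3 to compound 4 (beyond the scatter) on one core against a number 11 percentage points lower from compound 2 to compound 1 (beyond the scatter) on the other. The two steps run in opposite directions, so for these two cores the direction of the change does not carry from one to the other, and a step read on one core is a poor guide to the other. This rests on one pair per core and does not show how other cores would behave, and no measurement bearing on the cause of the reversal is available.

Open, from the compounds shown here alone, is whether an ethyl or longer chain on that oxygen would follow either step on either core. Also open, going by these compounds, is how an amine in place of the hydroxy would read on the two cores.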